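Triazolylmethyl spirooxindoles: aryl swap on the triazole nitrogen

This account rests on a few compounds, and the source may have more. Where it says the series, first, only, none or still open, it means among the compounds named here.

Three members of the series have been measured in a functional assay on HepG2 cells (Homo sapiens) for antiproliferative activity, read by MTT assay, with a stated time of 48 h; a higher number here means a weaker inhibitor, a lower number a stronger inhibitor. Compound 1 `Cc1ccccc1-n1nncc1CN1C(=O)C2(C(C#N)=C(N)Oc3c2c2nc4ccccc4nc2c2ccccc32)c2ccccc21` reaches only the limit of the assay, > 50000 nM. Compound 2 `CCOc1ccccc1-n1nncc1CN1C(=O)C2(C(C#N)=C(N)Oc3c2c2nc4ccccc4nc2c2ccccc32)c2ccccc21` likewise reaches only the limit, > 50000 nM. The step that the two limits leave unreadable from compound 1 to compound 2 is therefore unreadable, since both ends sit at the limit described by the limit of > 50000 nM in this assay, at which 2 of the 3 values shown sit. For the measured compounds named here, compound 3 `CCc1ccccc1-n1nncc1CN1C(=O)C2(C(C#N)=C(N)Oc3c(N)cc4nc5ccccc5nc4c32)c2ccccc21`, which carries a different core from the first two, is the one member with a numerical value: in this assay compound 3 gives 17900 nM, and it stands as the only number among the three values shown.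

Compound 4 `N#CC1=C(N)Oc2c(N)cc3nc4ccccc4nc3c2C12C(=O)N(Cc1cnnn1-c1cc(Cl)ccc1Cl)c1ccccc12` keeps the core of compound 3 and differs from it by 2,5-dichlorophenyl in place of 2-ethylphenyl on an aromatic nitrogen. Going by the values given here, no measured step bears on this change: the single step available, from compound 1 to compound 2, is unreadable and concerns a different core and a different kind of substituent. With nothing to read, no change beyond the scatter is expected from this aryl swap. Compound 4 is therefore expected to give about 18000 nM in this assay, within 6000 nM to 50000 nM, which means an expected step of a 1.0-fold higher number from compound 3 to compound 4 (0.00 log units; within the scatter). Given how close compound 3 already sits to the limit of the assay, a limit rather than a number is a real possibility for compound 4.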

Compound 4, half-maximal inhibitory concentration: 33100 nM
Estimate against measurement, compound 4: 1.8-fold (0.26 log units) below; low and high end bracket the measured number.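

For the compounds shown here, on the core of compound 3, the aryl swap on the aromatic nitrogen gives the first readable step in this assay: a 1.8-fold higher number from compound 3 to compound 4 (0.27 log units; within the scatter). On this core, therefore, 2-ethylphenyl and 2,5-dichlorophenyl cannot be told apart, even though two chlorine atoms enter and the ethyl group leaves. Compound 3 and compound 4 both give numbers, while the other two values shown are limits of the assay rather than numbers: the limit of > 50000 nM in this assay, at which 2 of the 4 values shown sit.

The step between the two compounds with limits cannot be read, and no pair shown differs in the core alone, so the contribution of the core stays unknown. Also open, on these data alone, is whether an aryl group on this nitrogen carrying an amine, a carboxylic acid or a longer chain would move the number beyond the scatter, since the two groups compared here, both phenyl rings bearing only alkyl or chlorine substituents, cover little of what this position could hold.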